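Removing a Methyl Group: Does the Earlier Gain Repeat?

This account rests on a few compounds, and the source may have more. Where it says the series, first, only, none or still open, it means among the compounds named here.

Of the compounds shown here, three with a shared core have been tested in a functional assay on SK-OV-3 cells (Homo sapiens) for cytotoxicity, read by MTT assay, with a stated time of 48 h; a lower number here means a stronger inhibitor, a higher number a weaker inhibitor. Compound 1, `O=c1[nH]c2ccccc2cc1-c1nc2cc(F)ccc2[nH]1`, gives 18300 nM. Compound 3, `Cc1ccc2[nH]c(=O)c(-c3nc4cc(F)ccc4[nH]3)cc2c1`, reaches only a limit of the assay, > 100000 nM, which is not a number. Compound 2, `Cc1ccc2[nH]c(=O)c(-c3nc4cc(C)c(C)cc4[nH]3)cc2c1`, likewise stops at the limit of > 100000 nM in this assay, at which 2 of the 3 values shown sit, recorded as > 100000 nM. Compound 3 and compound 1 differ in one place, (hydrogen in place of methyl on an aromatic carbon), and this change brought an at least 5.4-fold lower number from compound 3 to compound 1 (0.73 log units; beyond the scatter) in this assay. How the core of compound 2 differs from that of compound 3 is not broken down here.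

Compound 4, `Cc1cc2nc(-c3cc4ccccc4[nH]c3=O)[nH]c2cc1C`, has not yet been measured in this assay. Among the compounds with values here, it differs from compound 2 by hydrogen in place of methyl on an aromatic carbon, the same change at the same place as the one that turned compound 3 into compound 1. Because that earlier change brought an at least 5.4-fold lower number from compound 3 to compound 1 (0.73 log units; beyond the scatter), a step of similar size is expected from the limit of compound 2 toward a real number, roughly an at least 3.3-fold lower number from compound 2 to compound 4 (0.52 log units; beyond the scatter). Compound 4 is therefore estimated at 30000 nM, within 10000 nM to 100000 nM, though the result may again remain a limit.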

Compound 4, half-maximal inhibitory concentration: > 100000 nM
Compound 4: no number, only a limit; the forecaster's own chance of this, stated with the estimate: 35%; middle value at least 3.3-fold (0.52 log units) from the limit.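

In this assay compound 4 gives only a limit, > 100000 nM, and compound 2 also stops at a limit, so no step can be read between compound 2 and compound 4: the limit of > 100000 nM in this assay, at which 3 of the 4 values shown sit.

The compounds shown leave open whether hydrogen in place of methyl lowers the number for compound 2 at all, as it did for compound 3.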